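Two Chlorines on the Sulfonyl Aryl Ring

A few compounds are considered here, and "the series" means these few. Any claim that something is new, unique, unknown or untested is made for them only; others in the source may bear on it.

compound 1 `O=S(=O)(c1cccc(C(F)(F)F)c1)c1cn(C2CCNC2)c2ncccc12`: 41%
compound 2 `O=S(=O)(c1ccccc1Cl)c1cn(C2CCCNC2)c2ncccc12`: 84%

In a functional assay on HeLa cells for agonist activity at 5-hydroxytryptamine receptor 6 (Homo sapiens), read by cAMP accumulation and immunoassay (a lower number here means a smaller maximal response, a higher number a larger maximal response), compound 2 gives 84%, the higher of the two numbers; compound 1 gives 41%, a gap beyond the usual scatter. Compound 3 `O=S(=O)(c1cc(Cl)cc(Cl)c1)c1cn(C2CCCNC2)c2ncccc12` differs from compound 2 by one change: 3,5-dichlorophenyl in place of 2-chlorophenyl on a sulfonyl sulfur. Among the measured compounds shown here, no measured pair shows this same change, and compounds 1 and 2 differ in more than one place, so the data give no direct guide to its size. A moderate fall, somewhat beyond the scatter, is expected, the step from compound 2 to compound 3 being a number 19 percentage points lower from compound 2 to compound 3 (beyond the scatter). Compound 3 is estimated at 65%, between 35% and 95%.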

Compound 3, largest response reached (Emax), in percent of the reference or control that the assay uses: 62%
Beside the measured number, compound 3's estimate is 3 percentage points above it, within the range that was stated.
By their numbers in this assay, from the lowest: compound 1; then compound 3; then compound 2.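

With the rest of the molecule unchanged, 3,5-dichlorophenyl in place of 2-chlorophenyl on a sulfonyl sulfur gives a number 22 percentage points lower from compound 2 to compound 3 (beyond the scatter) in this assay and so shows that the maximal response depends on this aryl group. The change both adds a chlorine and alters where chlorine sits, and this single step cannot separate the two. No measurement shown explains the fall.

Still open, going by these compounds, is whether an unsubstituted phenyl, or a phenyl carrying a methoxy group or a nitrile, on this sulfonyl sulfur would match compound 2 or fall further.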